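A few compounds are considered here, and "the series" means these few. Any claim that something is new, unique, unknown or untested is made for them only; others in the source may bear on it.

Working notes on the series.

Compound 1 `O=c1nc2oc(C3CC3)c(C#CC3CC3)c2cn1Cc1cn(Cc2ccccc2)nn1` is the reference point; in a functional assay on HeLa cells (Homo sapiens) for antiproliferative activity, read by MTT assay, with a stated time of 72 h (a higher number here means a weaker inhibitor, a lower number a stronger inhibitor), compound 1 gives 6510 nM. Within the data shown here, the only other measured member, compound 2 `O=c1nc2oc(C3CC3)c(C#CC3CC3)c2cn1Cc1cn(-c2ccc(Cl)cc2)nn1`, in this assay gives 16100 nM. Among the measured compounds shown here, compound 1 therefore stands at the lowest of the two numbers; the single measured step is a 2.5-fold higher number from compound 1 to compound 2 (0.39 log units; beyond the scatter), and it concerns the group on the triazole nitrogen, not the fused core.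

Compound 3 `O=c1nc2oc(C3CC3)cc2cn1Cc1cn(Cc2ccccc2)nn1` differs from compound 1 by hydrogen in place of 2-cyclopropylethynyl on an aromatic carbon. For the measured compounds named here, no measured step touches this part of the core: the step from compound 1 to compound 2 changes a different place and gives no guide to the size or direction of the change here. The expectation for compound 3 in this assay therefore rests on the value of compound 1 alone, with a broad range, and it is expected that removing a group of this size in the core more likely moves the number up than down. The estimate for compound 3 is 15000 nM, expected within 4000 nM to 60000 nM. This estimate corresponds to an expected step of a 2.3-fold higher number from compound 1 to compound 3 (0.36 log units; beyond the scatter).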

Compound 3, half-maximal inhibitory concentration: 50000 nM
Estimate against measurement, compound 3: 3.3-fold (0.52 log units) below; the range from low to high includes it.
By their numbers in this assay, from the lowest: compound 1; then compound 2; then compound 3.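

In this assay, among these compounds, the 2-cyclopropylethynyl group on the aromatic carbon is the first part of the shared core with a measured step: hydrogen in its place gives a 7.7-fold higher number from compound 1 to compound 3 (0.89 log units; beyond the scatter) and so shows that the number at this position responds to the change, in the upward direction, when the group leaves. The change takes away the triple bond and the three-membered ring together, so the step cannot say which part of the group accounts for the difference. Nothing measured here bears on why the number moves with this change.

Left open is whether another group on this carbon, such as a plain ethynyl, a methyl or a phenylethynyl, would keep the number of compound 1, raise it or lower it. Among the compounds shown here, also open is whether 4-chlorophenyl in place of benzyl on the aromatic nitrogen would give a similar step with hydrogen on this carbon, as no pair of compounds with that hydrogen differs at the nitrogen.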